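The source may report more compounds than this note shows. Statements on the series, on what has been measured and on what is new or still open speak of the compounds shown alone.

Compound 1 `COc1cc2c(Oc3ccc(NC(=O)Nc4ccccc4)cc3)ccnc2cc1OCCCCCCC(=O)NO` is the reference point here. In a functional assay on MCF7 cells (Homo sapiens) for antiproliferative activity, read by MTT assay (a higher number here means a weaker inhibitor, a lower number a stronger inhibitor), compound 1 gives 1040 nM, the second highest of the three numbers: compound 2 `COc1cc2c(Oc3ccc(NC(=O)Nc4ccc(OC(F)(F)F)cc4)cc3)ccnc2cc1OCCCCCCC(=O)NO` gives 3200 nM and compound 3 `COc1cc2c(Oc3ccc(NC(=O)NC4CCCCC4)cc3)ccnc2cc1OCCCCCCC(=O)NO` gives 600 nM. The step of a 3.1-fold higher number from compound 1 to compound 2 (0.49 log units; beyond the scatter) follows trifluoromethoxy in place of hydrogen on an aromatic carbon; the step of a 1.7-fold lower number from compound 1 to compound 3 (0.24 log units; within the scatter) follows cyclohexyl in place of phenyl on an amide-type nitrogen; a 5.3-fold lower number from compound 2 to compound 3 (0.73 log units; beyond the scatter) links those two. Compound 4 `COc1cc2c(Oc3ccc(NC(=O)N/N=C/c4ccc(F)cc4)cc3)ccnc2cc1OCCCCCCC(=O)NO` differs from compound 1 by a group of 9 heavy atoms (7 carbon, 1 nitrogen, 1 fluorine; one six-membered aromatic ring of carbon only) in place of a group of 6 heavy atoms (6 carbon; one six-membered aromatic ring of carbon only), on an amide-type nitrogen. Both steps from compound 1 bear on it: one modest rise with added substitution on the phenyl, one change at the same nitrogen within the scatter. The expected step of a 1.4-fold higher number from compound 1 to compound 4 (0.16 log units; within the scatter) is therefore small, leaning towards a higher number. Compound 4 is expected to give 1500 nM, within 500 nM to 4500 nM.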

Compound 4, half-maximal inhibitory concentration: 1360 nM
For compound 4 the middle estimate is 1.1-fold (0.04 log units) above the measured one; the measured number falls inside the stated range.
By their numbers in this assay, from the lowest: compounds 3, 1 and 4 (each within the scatter of the next, the first and the last beyond it); then compound 2.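

In this assay, the group of 9 heavy atoms, with its double bond outside aromatic rings and its hydrogen-bond acceptor, can stand on the amide-type nitrogen in place of phenyl with only a 1.3-fold higher number from compound 1 to compound 4 (0.12 log units; within the scatter). The other two steps separate it from both earlier groups: a 2.3-fold higher number from compound 3 to compound 4 (0.36 log units; beyond the scatter) and a 2.4-fold lower number from compound 2 to compound 4 (0.37 log units; beyond the scatter). A larger group on this nitrogen therefore need not reach the number of compound 2.

Nothing available explains these differences. Also open, on these data alone, is whether an amine or a carboxylic acid in place of the fluorine would shift the number.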